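Swapping the Amide Group on Compound 2

The compounds below may be only part of what the source reports. "The series", "measured", "known", "first", "only" and "open" are said of these compounds alone.

Values in a functional assay on MIA PaCa-2 cells (Homo sapiens) for inhibition, read by MTT assay, with a stated time of 7 days; a higher number here means a weaker inhibitor, a lower number a stronger inhibitor:
- Compound 1 `CCN(CC)S(=O)(=O)c1ccc(S(=O)(=O)N2CCC[C@@H](C(=O)N3CCC(O)CC3)C2)cc1`: 870 nM
- Compound 2 `CCN(CC)S(=O)(=O)c1ccc(S(=O)(=O)N2CCC[C@@H](C(=O)NC3CCOCC3)C2)cc1`: 3770 nM

Compound 2 has the higher number of the two, at 3770 nM, which makes it the weaker inhibitor so far. Compound 3 `CCN(CC)S(=O)(=O)c1ccc(S(=O)(=O)N2CCC[C@@H](C(=O)N[C@H]3CC[C@@H](OC)CC3)C2)cc1` keeps the shared core and carries 4-methoxycyclohexyl in place of oxan-4-yl on an amide-type nitrogen. Within the data shown here, only one measured step bears on this change, and it gives a 4.3-fold higher number from compound 1 to compound 2 (0.64 log units; beyond the scatter). That step altered the group on the same carbonyl carbon, so it shows that this part of the molecule can move the number in this assay. It gives no direction for the new group, so a change no larger than that modest step seems reasonable. The expected change is a 1.3-fold lower number from compound 2 to compound 3 (0.13 log units; within the scatter). For compound 3 the estimated value is 2800 nM, with an expected range of 1000 nM to 8000 nM.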

Compound 3, half-maximal inhibitory concentration: 960 nM
Compound 3: middle estimate off by 2.9-fold (0.46 log units), on the high side; the measured number lies below the stated range.
By their numbers in this assay, from the lowest: compounds 1 and 3 (each within the scatter of the next); then compound 2.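

Replacing oxan-4-yl with 4-methoxycyclohexyl on the amide-type nitrogen changes the result in this assay (a 3.9-fold lower number from compound 2 to compound 3 (0.59 log units; beyond the scatter)), so this group alone can shift the number, even with the amide hydrogen kept in both compounds. Exchanging 4-hydroxypiperidin-1-yl on the carbonyl carbon for (4-methoxycyclohexyl)amino leaves the two compounds within the usual scatter (a 1.1-fold higher number from compound 1 to compound 3 (0.04 log units; within the scatter)), so the amide hydrogen present in compound 3 and absent from compound 1 does not by itself set the number in this pair. No supporting measurement explains either step.

A plain cyclohexyl group would help separate the contribution of the carbon-only ring from that of the methoxy group. From the compounds shown here alone, the opposite arrangement of the two defined stereocentres in 4-methoxycyclohexyl and an amine in place of its methoxy group also remain open.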